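Chloro for methoxy on the pendant aryl of compound 2

This account rests on a few compounds, and the source may have more. Where it says the series, first, only, none or still open, it means among the compounds named here.

Compound 1 `COc1ccc(C2=NN(C3=NC(=O)/C(=C4\C(=O)Nc5ccccc54)S3)C(c3ccc(OC)cc3)C2)cc1` gives 99600 nM in a functional assay on cells (Cancer cell lines, Homo sapiens) for cytotoxicity, read by sulforhodamine B assay, with a stated time of 48 h; on this read-out lower numbers stand for stronger inhibition of growth and higher numbers for weaker inhibition of growth.
Compound 2 `COc1ccc(C2=NN(C3=NC(=O)/C(=C4\C(=O)Nc5ccc(Br)cc54)S3)C(c3ccc(OC)cc3)C2)cc1` gives 480 nM in this assay.
Compound 3 `COc1ccc(C2CC(c3ccc4ccccc4c3)=NN2C2=NC(=O)/C(=C3\C(=O)Nc4ccc(Br)cc43)S2)cc1` gives 990 nM in this assay.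

Compound 2 has the lowest number of the three. The bromo step, a 210-fold lower number from compound 1 to compound 2 (2.32 log units; beyond the scatter), is the large one in this set; the aryl swap, a 2.1-fold higher number from compound 2 to compound 3 (0.31 log units; beyond the scatter), is modest. Compound 4 `COc1ccc(C2=NN(C3=NC(=O)/C(=C4\C(=O)Nc5ccc(Br)cc54)S3)C(c3ccc(Cl)cc3)C2)cc1` differs from compound 2 by chloro in place of methoxy on an aromatic carbon. Going by the values given here, no measured step touches this position, so only the modest aryl swap a 2.1-fold higher number from compound 2 to compound 3 (0.31 log units; beyond the scatter) offers a guide, and the bromo remains in place. A small step is therefore expected, a 1.5-fold higher number from compound 2 to compound 4 (0.16 log units; within the scatter), most likely a slight rise in number. Compound 4 is estimated at 700 nM, in the range 250 nM to 2500 nM.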

Compound 4, concentration for total growth inhibition: 400 nM
Estimate against measurement, compound 4: 1.8-fold (0.24 log units) above; measured number inside the range.
By their numbers in this assay, from the lowest: compounds 4 and 2 (each within the scatter of the next); then compound 3; then compound 1.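

Going by these compounds alone, no earlier compound varies this position. In this assay, 4-methoxyphenyl to 4-chlorophenyl gives a 1.2-fold lower number from compound 2 to compound 4 (0.08 log units; within the scatter), so with the bromo in place, the hydrogen-bond acceptor counted on methoxy is not required at this position for this read-out. Nothing at hand explains why the two groups read alike.

Still open, on these data alone, is whether an amine or a carboxylic acid on this aromatic carbon would stay within the scatter of compound 2. Also open, as far as these compounds go, is whether chloro reads the same way without the bromo.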